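A few compounds are considered here, and "the series" means these few. Any claim that something is new, unique, unknown or untested is made for them only; others in the source may bear on it.

Measured compounds:
Compound 1 `Cc1ccc2nc(Nc3nc(Nc4ccc(S(N)(=O)=O)cc4)ncc3F)sc2c1`, which in a functional assay on PC-3 cells (Homo sapiens) for antiproliferative activity, read by MTT assay, with a stated time of 48 h (a lower number here means a stronger inhibitor, a higher number a weaker inhibitor), gives 4960 nM.
Compound 2 `Cc1cnc(Nc2ccc(S(C)(=O)=O)cc2)nc1Nc1nc2ccc(Cl)cc2s1`, which in this assay gives 13400 nM.

Of the two numbers seen in this assay, compound 2 holds the higher one; its nearest neighbour is compound 1, whose number is lower by a gap beyond the usual scatter. Among the measured compounds shown here, compound 2 and compound 1 differ in more than one place, so their two values show only that compound 2 is the weaker of the pair.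

Compound 3 `Cc1cnc(Nc2ccc(S(C)(=O)=O)cc2)nc1Nc1nc2ccccc2s1` differs from compound 2 in one place only: hydrogen in place of chloro on an aromatic carbon. For the measured compounds named here, no pair of measured compounds isolates this change, so the step must be judged without a direct precedent. Losing a single chlorine atom is a small alteration by count, and the account expects a step of modest size in this assay: the estimated step of a 1.5-fold higher number from compound 2 to compound 3 (0.17 log units; within the scatter) leans toward a somewhat higher number, with no step beyond the scatter being nearly as likely. Compound 3 is therefore estimated at 20000 nM, within a range from 7000 nM to 55000 nM.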

Compound 3, half-maximal inhibitory concentration: > 50000 nM
Compound 3: no number, only a limit; the forecaster's own chance of this, stated with the estimate: 15%; middle value at least 2.5-fold (0.39 log units) from the limit.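

In this assay compound 3 gives > 50000 nM as a limit of the assay and not a number. Hydrogen in place of chloro on this aromatic carbon is the only change here isolated at one place, and it gives an at least 3.7-fold higher number from compound 2 to compound 3 (0.57 log units; beyond the scatter) and so shows that, in this pair, the stronger inhibition goes with the chloro compound, although only a single heavy atom leaves. The step can be stated only as a lower bound, and its true size stays unknown, because the value of compound 3 is capped: the limit of > 50000 nM in this assay, at which 1 of the 3 values shown sits.

The compounds shown leave open whether this effect belongs to chlorine itself or would follow other groups on the same carbon, and a fluorine, a methyl or a methoxy group there would help to separate those readings. They also leave open whether the same change would carry the same weight on the core of compound 1, so nothing here extends the finding beyond this one pair.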